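The compounds below may be only part of what the source reports. "The series", "measured", "known", "first", "only" and "open" are said of these compounds alone.

Compound 3 `CCCSc1cc(C)c(C(=O)N=C(N)N)cc1S(C)(=O)=O` gives 6.8 nM in a functional assay for inhibition of sodium/hydrogen exchanger (Oryctolagus cuniculus) (on this read-out lower numbers stand for stronger inhibition and higher numbers for weaker inhibition), the lowest of the three numbers shown, though not beyond the scatter from its neighbours. Compound 2 `Cc1cc(C2CCC2)c(S(C)(=O)=O)cc1C(=O)N=C(N)N` gives 8.2 nM and compound 1 `Cc1cc(C)c(S(C)(=O)=O)cc1C(=O)N=C(N)N` gives 11 nM. The three differ only at one aromatic carbon: a 1.3-fold lower number from compound 1 to compound 2 (0.13 log units; within the scatter), a 1.6-fold lower number from compound 1 to compound 3 (0.21 log units; within the scatter) and a 1.2-fold lower number from compound 2 to compound 3 (0.08 log units; within the scatter), so every exchange made there stayed within the scatter. Compound 4 `Cc1cc(O)c(S(C)(=O)=O)cc1C(=O)N=C(N)N` alters the same aromatic carbon: hydroxy in place of propylsulfanyl on an aromatic carbon. Within the data shown here, no measured step involves a hydroxy group, so the three flat steps are the only guide, and a step of a 1.5-fold higher number from compound 3 to compound 4 (0.17 log units; within the scatter) is expected, meaning no change beyond the scatter. Compound 4 is therefore estimated at 10 nM, in a range from 4 nM to 30 nM.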

Compound 4, half-maximal inhibitory concentration: 220 nM
Beside the measured number, compound 4's estimate is 22-fold (1.34 log units) below it, and the stated range ends below it.
By their numbers in this assay, from the lowest: compounds 3, 2 and 1 (each within the scatter of the next); then compound 4.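

In this assay, the aromatic carbon that had carried methyl, cyclobutyl and propylsulfanyl with no change beyond the scatter proves sensitive to hydroxy, which gives a 32-fold higher number from compound 3 to compound 4 (1.51 log units; beyond the scatter), a 27-fold higher number from compound 2 to compound 4 (1.43 log units; beyond the scatter) and a 20-fold higher number from compound 1 to compound 4 (1.30 log units; beyond the scatter). The flat picture therefore holds only for those three groups, and the step from methyl shows that a small group here does not by itself keep the number low. Nothing shown gives a reason for this loss. As far as these compounds go, whether a methoxy group or an amine at this carbon would stay with compounds 1 to 3 or fall with compound 4 remains open.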